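Ethyl to isopropyl on an anilinopyrimidine scaffold

A few compounds are considered here, and "the series" means these few. Any claim that something is new, unique, unknown or untested is made for them only; others in the source may bear on it.

Measured compounds:
compound 1 `Cc1ccccc1Nc1nc(Nc2ccc(N3CCN(C)CC3)cc2)ncc1Cl` with 13700 nM
compound 2 `CCN1CCN(c2ccc(Nc3ncc(Cl)c(Nc4ccccc4C)n3)cc2)CC1` with 2060 nM
compound 3 `CCc1ccc(Nc2nc(Nc3ccc(N4CCN(C)CC4)cn3)ncc2Cl)cc1` with 11100 nM

In a functional assay on Jurkat cells (Homo sapiens) for inhibition, read by CCK-8 assay, with a stated time of 48 h (on this read-out higher numbers stand for weaker inhibition of growth and lower numbers for stronger inhibition of growth), compound 1 gives 13700 nM and compound 2 gives 2060 nM; the change methyl in place of hydrogen on a saturated chain carbon bound to an amine nitrogen in a ring brought a 6.7-fold lower number from compound 1 to compound 2 (0.82 log units; beyond the scatter). Compound 3 gives 11100 nM in this assay. The difference between the cores of compound 1 and compound 3 is not broken down here. Compound 4 `CC(C)c1ccc(Nc2nc(Nc3ccc(N4CCN(C)CC4)cn3)ncc2Cl)cc1` has not yet been measured; it differs from compound 3 by methyl in place of hydrogen on a saturated chain carbon bound to an aromatic carbon and a saturated chain carbon. This is the same kind of change as that from compound 1 to compound 2, not the same: there the added methyl sits on a saturated chain carbon bound to an amine nitrogen in a ring, whereas here it sits on a saturated chain carbon bound to an aromatic carbon and a saturated chain carbon. Within the data shown here, because the only precedent, a 6.7-fold lower number from compound 1 to compound 2 (0.82 log units; beyond the scatter), comes from a different place, the expected step from compound 3 to compound 4 in this assay is smaller, a 1.5-fold lower number from compound 3 to compound 4 (0.17 log units; within the scatter). Compound 4 is estimated at 7500 nM, between 2500 nM and 25000 nM.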

Compound 4, concentration for 50% growth inhibition: 7530 nM
Compound 4: middle estimate off by 1.0-fold (0.00 log units), on the low side; the range from low to high includes it.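

In this assay, the change from ethyl to isopropyl gave a 1.5-fold lower number from compound 3 to compound 4 (0.17 log units; within the scatter), so the 4-isopropylphenyl group cannot be told apart from the 4-ethylphenyl group here. Set beside the earlier methyl addition, the two steps do not agree: the same change on two cores in this assay, a 6.7-fold lower number (0.82 log units; beyond the scatter) from compound 1 to compound 2 and a 1.5-fold lower number (0.17 log units; within the scatter) from compound 3 to compound 4, 4.5-fold (0.65 log units) apart, beyond the scatter of two such steps. This shows that the size of a step from adding a methyl did not carry from one core to the other, but it does not show whether the core or the place of the methyl accounts for the gap, as the two pairs differ in both.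

On these data alone, it remains open whether a longer chain or a cyclopropyl group in place of the isopropyl would move the number beyond the scatter. Also open, as far as these compounds go, is whether a methyl added on a saturated chain carbon bound to an amine nitrogen in a ring would give as large a step on the core of compound 3 as on the core of compound 1.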